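The source may hold more compounds than are shown below. What is called first, only, known or untested is meant among the compounds shown, and "the series" means these compounds.

Working notes on the series. Three compounds share one core: compound 1 `c1ccc2c(c1)CN[C@@H](CN(CCCCNCC1CCOCC1)[C@H]1CCCc3cccnc31)C2`, compound 2 `CC(C)(CN)CCN(C[C@H]1Cc2ccccc2CN1)[C@H]1CCCc2cccnc21` and compound 3 `CC(C)(CCN(C[C@H]1Cc2ccccc2CN1)[C@H]1CCCc2cccnc21)CNCC1CCOCC1`. In a functional assay on cells for agonist activity at C-X-C chemokine receptor type 4 (Homo sapiens), read by fluorescence and calcium flux, with a stated time of 90 s (on this read-out higher numbers stand for an effect only at larger amounts of compound and lower numbers for an effect already at smaller amounts), compound 1 gives > 30000 nM, which is a limit of the assay and not a number. Compound 2 likewise reaches only a limit in this assay, at > 30000 nM. Compound 3 also stands at a limit in this assay, > 30000 nM, so no number is known for it. The steps a step that the two limits leave unreadable from compound 1 to compound 2, a step that the two limits leave unreadable from compound 1 to compound 3 and a step that the two limits leave unreadable from compound 2 to compound 3 cannot be sized or given a direction, since (the limit of > 30000 nM in this assay, at which 3 of the 3 values shown sit).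

Compound 4 `CC(C)(CCN(C[C@H]1Cc2ccccc2CN1)[C@H]1CCCc2cccnc21)CNC1CCC(F)(F)CC1` differs from compound 3 by 4,4-difluorocyclohexyl in place of (oxan-4-yl)methyl on an amine nitrogen. The step from compound 2 to compound 3 touches the same amine nitrogen, but with both ends at the limit it tells nothing about the size of such a change. With every measured value in this assay sitting at the limit, no step size or direction can be derived for compound 4, and the plain expectation is that compound 4 again reaches only the limit. Compound 4 is therefore estimated at about 30000 nM in this assay, with a range from 10000 nM to 100000 nM. The expected step of a number no higher from compound 3 to compound 4 (the limit leaves the size open) is accordingly put at none beyond the scatter.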

Compound 4, half-maximal effective concentration: > 30000 nM
Compound 4 gave a limit, no number; the forecaster's own chance of this, stated with the estimate: 85%; the middle value lies on the limit itself.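

No step from compound 2 or compound 3 to compound 4 can be read in this assay, because these compounds give only limits and no numbers: the limit of > 30000 nM in this assay, at which 4 of the 4 values shown sit.

The compounds shown leave open whether any group on this amine nitrogen gives a measurable half-maximal effective concentration, and how large a change between such groups would be.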